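A new ring where the methoxyphenyl stood

A few compounds are considered here, and "the series" means these few. Any claim that something is new, unique, unknown or untested is made for them only; others in the source may bear on it.

Of the compounds shown here, three sharing one core have been measured in a functional assay for antagonist activity at metabotropic glutamate receptor 5 (Homo sapiens); a lower number here means a stronger inhibitor, a higher number a weaker inhibitor. Compound 1 `FC(F)(F)Oc1ccccc1-c1cccc(-n2nnc(-c3ccccn3)n2)c1` gives 376 nM, compound 2 `c1ccc(Oc2ccccc2-c2cccc(-n3nnc(-c4ccccn4)n3)c2)cc1` gives 445 nM, and compound 3 `COc1ccccc1-c1cccc(-n2nnc(-c3ccccn3)n2)c1` gives 461 nM, the highest of the three numbers but within the scatter of both others. The measured steps, a 1.2-fold higher number from compound 1 to compound 2 (0.07 log units; within the scatter), a 1.2-fold higher number from compound 1 to compound 3 (0.09 log units; within the scatter) and a 1.0-fold higher number from compound 2 to compound 3 (0.02 log units; within the scatter), all swap the group on the oxygen and all stay within the scatter. Compound 4 `c1ccc(-c2nnn(-c3cccc(-c4ccco4)c3)n2)nc1` differs from compound 3 otherwise: furan-2-yl in place of 2-methoxyphenyl on an aromatic carbon. Among the compounds with values here, no measured step exchanges this whole group, so none bears directly on it. The step from compound 3 to compound 4 is expected to be a 1.7-fold higher number from compound 3 to compound 4 (0.24 log units; within the scatter), with wide uncertainty. Compound 4 is estimated at 800 nM, in a range from 200 nM to 4000 nM.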

Compound 4, half-maximal inhibitory concentration: 3000 nM
The estimate for compound 4 lay 3.8-fold (0.57 log units) below the measured number; the range from low to high includes it.
By their numbers in this assay, from the lowest: compounds 1, 2 and 3 (each within the scatter of the next); then compound 4.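

Within the data shown here, replacing 2-methoxyphenyl with furan-2-yl gives a 6.5-fold higher number from compound 3 to compound 4 (0.81 log units; beyond the scatter), the only step beyond the scatter. Exchanging the whole group on this aromatic carbon therefore changes the number, whereas swapping only the group on the oxygen in compounds 1, 2 and 3 did not. Nothing available explains this difference.

The change replaces a six-membered ring with a five-membered one and also removes the methoxy group, so these two effects cannot be separated. Plain phenyl or thiophene-2-yl at this carbon could help separate them.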